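This account rests on a few compounds, and the source may have more. Where it says the series, first, only, none or still open, it means among the compounds named here.

Measured so far in a functional assay on PC-3 cells (Homo sapiens) for cytotoxicity, read by MTT assay, with a stated time of 72 h; a higher number here means a weaker inhibitor, a lower number a stronger inhibitor:
compound 1 `CCCCCCNc1nc(SCc2ccc(C(F)(F)F)cc2)nc2ccccc12` gives 19000 nM
compound 2 `FC(F)(F)c1ccc(CSc2nc(Nc3ccccc3)c3ccccc3n2)cc1` gives 20000 nM
compound 3 `Fc1ccc(Nc2nc(SCc3ccc(C(F)(F)F)cc3)nc3ccccc23)cc1` gives 7070 nM

Compound 1 stands second highest of the three numbers. Its nearest neighbour is compound 2, with a 1.1-fold higher number from compound 1 to compound 2 (0.02 log units; within the scatter); its furthest is compound 3, with a 2.7-fold lower number from compound 1 to compound 3 (0.43 log units; beyond the scatter). Compound 4 `COc1ccc(Nc2nc(SCc3ccc(C(F)(F)F)cc3)nc3ccccc23)cc1` has not yet been run in this assay. Against compound 1 the change is 4-methoxyphenyl in place of hexyl on a nitrogen on an aromatic ring.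

Going by the values given here, two measured steps bear on this change, both replacing hexyl on the same nitrogen with an aromatic ring. Phenyl in place of hexyl gave a 1.1-fold higher number from compound 1 to compound 2 (0.02 log units; within the scatter). 4-fluorophenyl in place of hexyl gave a 2.7-fold lower number from compound 1 to compound 3 (0.43 log units; beyond the scatter), and within the aryl pair the fluoro in place of hydrogen gave a 2.8-fold lower number from compound 2 to compound 3 (0.45 log units; beyond the scatter). An aryl group on this nitrogen has therefore either left the number where it was or lowered it modestly. No measured compound carries methoxy on the ring, so whether methoxy follows fluoro or follows the bare phenyl is not shown by the data. The expectation is a step somewhere between the two, leaning to a small lowering. Compound 4 is therefore expected to show a 1.5-fold lower number from compound 1 to compound 4 (0.16 log units; within the scatter). Compound 4 is estimated at 13000 nM, with a range from 5000 nM to 30000 nM.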

Compound 4, half-maximal inhibitory concentration: 16700 nM
Compound 4: the middle estimate sits 1.3-fold (0.11 log units) below what was measured, within the range that was stated.
By their numbers in this assay, from the lowest: compound 3; then compounds 4, 1 and 2 (each within the scatter of the next).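

In this assay, 4-methoxyphenyl on this nitrogen does not separate from hexyl, with a 1.1-fold lower number from compound 1 to compound 4 (0.06 log units; within the scatter), nor from the bare phenyl, with a 1.2-fold lower number from compound 2 to compound 4 (0.08 log units; within the scatter), so methoxy on the aromatic ring does not carry over the lowering seen with fluoro. Methoxy in place of fluoro on the same aromatic carbon gives a 2.4-fold higher number from compound 3 to compound 4 (0.37 log units; beyond the scatter), which leaves compound 3 as the only one of the four set apart from the others and shows that an aromatic ring on this nitrogen does not by itself lower the number. Nothing measured here bears on why fluoro and methoxy differ at this place.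

From the compounds shown here alone, with only hydrogen, fluoro and methoxy on the ring, it remains open whether chloro or a nitrile on that aromatic carbon would follow fluoro or methoxy. Also open, going by these compounds, is whether a benzyl group or a shorter chain such as butyl on this nitrogen would stay with compound 1 or move towards compound 3 in this assay.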